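Methoxy removal on the aromatic ring: three points, one gap

This account rests on a few compounds, and the source may have more. Where it says the series, first, only, none or still open, it means among the compounds named here.

The series keeps one core and differs only in how methoxy groups are placed on a six-membered aromatic ring of carbon only. Compound 1 `CCC1=C(O)c2c(oc(-c3ccccc3OC)cc2=O)C(CC)(CC)C1=O`, compound 3 `CCC1=C(O)c2c(oc(-c3cccc(OC)c3OC)cc2=O)C(CC)(CC)C1=O` and compound 2 `CCC1=C(O)c2c(oc(-c3cc(OC)c(OC)c(OC)c3)cc2=O)C(CC)(CC)C1=O` are the measured members. In a functional assay on KB cells (Homo sapiens) for antiproliferative activity, read by sulforhodamine B assay, with a stated time of 3 days (a higher number here means that more compound is needed for the effect, a lower number that less compound is needed), compound 1 gives 40.8 uM. Compound 3 gives 35.2 uM in this assay, and compound 2 gives 46.7 uM. All three values lie within the scatter of one another, so no order among them can be read. Among the compounds with values here, the single measured one-place step is a 1.2-fold higher number from compound 3 to compound 1 (0.06 log units; within the scatter), made by hydrogen in place of methoxy on an aromatic carbon. The difference between the cores of compound 2 and compound 3 is not broken down here.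

Compound 4 `CCC1=C(O)c2c(oc(-c3cc(OC)cc(OC)c3)cc2=O)C(CC)(CC)C1=O` is not yet measured. It arises from compound 2 by hydrogen in place of methoxy on an aromatic carbon. This is the same kind of change as from compound 3 to compound 1, but the surroundings differ: there the leaving methoxy sits ortho to a methoxy group and meta to a large group, here ortho to two methoxy groups and para to a large group. The expectation rests on the step of a 1.2-fold higher number from compound 3 to compound 1 (0.06 log units; within the scatter) and on the three measured values all lying within the scatter of one another. The step of a 1.0-fold lower number from compound 2 to compound 4 (0.02 log units; within the scatter) is expected to stay within the scatter. Compound 4 is therefore expected to give 45 uM in this assay, with a range from 25 uM to 85 uM.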

Compound 4, concentration for half-maximal effect: 45.2 uM
Compound 4: the middle estimate sits 1.0-fold (0.00 log units) below what was measured; the measured number falls inside the stated range.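

In this assay, hydrogen in place of methoxy on an aromatic carbon gives a 1.0-fold lower number from compound 2 to compound 4 (0.01 log units; within the scatter), and the two cores compare as follows: the same change on two cores in this assay, a 1.2-fold higher number (0.06 log units; within the scatter) from compound 3 to compound 1 and a 1.0-fold lower number (0.01 log units; within the scatter) from compound 2 to compound 4, 1.2-fold (0.08 log units) apart, within the scatter of two such steps

On these two cores, then, the change carries over with no readable difference, even though the methoxy that leaves compound 2 sits ortho to two methoxy groups and para to a large group. This does not show that methoxy at these places is without any effect, since steps within the scatter cannot separate a small real effect from none, and two pairs give no rule for any other core or ring place.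

The compounds shown leave open whether a ring carrying no methoxy group at all, or one carrying a hydroxy group, a fluorine, an amine or a carboxylic acid in place of methoxy, would stay within the scatter of these values. They also leave open whether a longer chain in place of the ethyl groups on the shared core would give a number that can be told apart from those seen so far.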